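Carboxy in place of chloro in the series

The source may report more compounds than this note shows. Statements on the series, on what has been measured and on what is new or still open speak of the compounds shown alone.

Among the compounds with values here, in a functional assay for inhibition, with Homo sapiens as the target (on this read-out lower numbers stand for stronger inhibition and higher numbers for weaker inhibition), compound 1 (`COc1cc(OC)c(C(=O)/C=C/c2ccc(Cl)cc2)c(OC)c1`) gives 970 nM, the lower of the two numbers so far, and compound 2 (`COc1cc(OC)c(C(=O)/C=C/c2nccn2C)c(OC)c1`) gives 3800 nM. Compound 3 (`COc1cc(OC)c(C(=O)/C=C/c2ccc(C(=O)O)cc2)c(OC)c1`) carries carboxy in place of chloro on an aromatic carbon, para to a large group: carboxy in place of chloro on an aromatic carbon. Within the data shown here, only one measured step exists, a 3.9-fold higher number from compound 1 to compound 2 (0.59 log units; beyond the scatter), and it bears indirectly, as it swaps the whole 4-chlorophenyl for 1-methyl-1H-imidazol-2-yl. Among the measured compounds shown here, no measured step isolates the chloro position. A change of similar size towards weaker inhibition is expected, with the estimated step being a 5.2-fold higher number from compound 1 to compound 3 (0.71 log units; beyond the scatter). The estimate for compound 3 is 5000 nM, with an expected range of 1300 nM to 20000 nM.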

Compound 3, half-maximal inhibitory concentration: 6230 nM
The estimate for compound 3 lay 1.2-fold (0.10 log units) below the measured number, within the range that was stated.
By their numbers in this assay, from the lowest: compound 1; then compounds 2 and 3 (each within the scatter of the next).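

With only this one place changed, carboxy in place of chloro gives a 6.4-fold higher number from compound 1 to compound 3 (0.81 log units; beyond the scatter) in this assay and so the group on this aromatic carbon moves the read-out on its own, which the earlier step, swapping the whole 4-chlorophenyl, could not show. Nothing available accounts for the size of this step.

Open, from the compounds shown here alone, is whether the weaker inhibition follows from the entry of carboxy or from the loss of chloro. A methyl ester, an amine or plain hydrogen on the same carbon would separate the two.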